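Chain-linked diaryl ethers: moving the ring methyl

The source may report more compounds than this note shows. Statements on the series, on what has been measured and on what is new or still open speak of the compounds shown alone.

Measured compounds and their largest responses:
compound 1, `Cc1cc(C(=O)O)ccc1OCCCCOc1ccc(C(=O)CC(C)C)c(O)c1C`: 42.1%
compound 2, `CCCC(=O)c1ccc(OCCCCOc2ccc(C(=O)O)cc2C)c(C)c1O`: 40.5%
compound 3, `CCC(=O)c1ccc(OCCCCOc2ccc(C(=O)O)cc2C)c(C)c1O`: 22.7%

In an assay on HEK293 cells for positive allosteric modulation of metabotropic glutamate receptor 3 (Rattus norvegicus), read by thallium flux, with a stated time of 2.5 min (on this read-out higher numbers stand for larger maximal responses and lower numbers for smaller maximal responses), compound 1 and compound 2 sit within the scatter of each other, a number 1.6 percentage points lower from compound 1 to compound 2 (within the scatter), so neither can be set above the other. Compound 3 lies apart from both: a number 19.4 percentage points lower from compound 1 to compound 3 (beyond the scatter) and a number 17.8 percentage points lower from compound 2 to compound 3 (beyond the scatter), each a modest drop beyond the scatter. All three measured steps alter the saturated chain attached to the carbonyl; none touches the carboxyphenyl end of the molecule.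

Compound 4, `Cc1cc(OCCCCOc2ccc(C(=O)CC(C)C)c(O)c2C)ccc1C(=O)O`, is the next member. Against compound 1 the change is 4-carboxy-3-methylphenyl in place of 4-carboxy-2-methylphenyl on an oxygen on a saturated carbon. The carbonyl side chain is that of compound 1 and is left untouched, so the steps from compound 1 to compound 3 and from compound 2 to compound 3 do not bear on this change, and the step from compound 1 to compound 2 concerns a different part of the molecule altogether. Within the data shown here, no measured step speaks to the 4-carboxy-3-methylphenyl group in place of the 4-carboxy-2-methylphenyl group on an oxygen on a saturated carbon. The expectation is therefore no step beyond the scatter, a number 4.1 percentage points lower from compound 1 to compound 4 (within the scatter), carried with a wide range. Compound 4 is estimated at 38%, between 20% and 56%.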

Compound 4, largest response reached (reported as percent of maximum), in percent of the reference or control that the assay uses: 41.9%
For compound 4 the middle estimate is 3.9 percentage points below the measured one; the measured number falls inside the stated range.
By their numbers in this assay, from the lowest: compound 3; then compounds 2, 4 and 1 (each within the scatter of the next).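

In this assay, 4-carboxy-3-methylphenyl in place of 4-carboxy-2-methylphenyl on an oxygen on a saturated carbon gives a number 0.2 percentage points lower from compound 1 to compound 4 (within the scatter), so the two arrangements cannot be set apart on largest response. Among these compounds, this is the first reading from the carboxyphenyl end of the series, and it shows that, with the carbonyl side chain of compound 1 held fixed, this relocation of the ring methyl leaves the two compounds indistinguishable in this read-out, whereas the one step beyond the scatter so far lies in the saturated chain attached to the carbonyl, in the steps ending at compound 3. No supporting data on the compounds bear on why the two arrangements read alike.

As far as these compounds go, whether the same equivalence holds with the carbonyl side chains of compound 2 or compound 3 remains open, as compound 4 pairs this ring only with the side chain of compound 1. Also open, from the compounds shown here alone, is how this end of the molecule responds to a larger alteration, such as a chlorine in place of the ring methyl or a primary amide in place of the carboxylic acid.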